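A few compounds are considered here, and "the series" means these few. Any claim that something is new, unique, unknown or untested is made for them only; others in the source may bear on it.

Of the compounds shown here, three have been tested in an ADME assay on MRC5 cells (Homo sapiens) for cytotoxicity, read by fluorescence and resazurin assay, with a stated time of 3 days (on this read-out higher numbers stand for weaker inhibition and lower numbers for stronger inhibition), and all three reach only the edge of what it can read. Compound 1 `Cc1cn(C2CCN(Cc3cncc(Oc4cccc(Cl)c4)c3)CC2)c(=O)[nH]c1=O` gives only a limit there, > 64000 nM. Compound 2 `Cc1cccc(Oc2cccc(CN3CCC(n4cc(C)c(=O)[nH]c4=O)CC3)c2)c1` likewise gives only a limit in this assay, > 64000 nM. Compound 3 `Cc1cn(C2CCN(Cc3cccc(Oc4cccc(Cl)c4)n3)CC2)c(=O)[nH]c1=O` also stops at a limit, > 64000 nM. All three thus stand at the same point, (the limit of > 64000 nM in this assay, at which 3 of the 3 values shown sit), so no difference among them can be read from these numbers.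

Compound 4 `Cc1cn(C2CCN(Cc3cccc(Oc4cccc(Cl)c4)c3)CC2)c(=O)[nH]c1=O` has not yet been measured. It differs from compound 2 in one place: chloro in place of methyl on an aromatic carbon. In this assay this step is expected to bring no change beyond the scatter, a number no higher from compound 2 to compound 4 (the limit leaves the size open). Compound 4 is therefore expected to sit near 64000 nM, within 32000 nM to 128000 nM, most likely again reported as a limit rather than a number.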

Compound 4, half-maximal inhibitory concentration: 21000 nM
The estimate for compound 4 lay 3.0-fold (0.48 log units) above the measured number; the whole stated range lies above it.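

In this assay, the change from 3-methylphenoxy to 3-chlorophenoxy gives the first difference that can be read in this set: an at least 3.0-fold lower number from compound 2 to compound 4 (0.48 log units; beyond the scatter). Chloro in place of methyl at this place, meta to a large group, is therefore not a neutral swap on this read-out, and compound 4 gives a real number. The true size of the step stays open, since only a lower bound can be read from where compound 2 stands: the limit of > 64000 nM in this assay, at which 3 of the 4 values shown sit.

On these data alone, it remains open how other groups at this place, such as fluoro, methoxy or an amine, would read.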